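The source may hold more compounds than are shown below. What is called first, only, known or untested is meant among the compounds shown, and "the series" means these compounds.

For the measured compounds named here, compound 2 `CCc1nc2c(-c3ccc(Cl)cc3Cl)ccnc2n1C(CCOC)C1CCC1` gives 2.4 nM in an assay for binding affinity to Corticotropin releasing factor receptor (Rattus norvegicus) (on this read-out lower numbers stand for stronger inhibition and higher numbers for weaker inhibition), the higher of the two numbers so far, since compound 1 `CCc1nc2c(-c3ccc(Cl)cc3Cl)ccnc2n1C(C)C1CCC1` gives 1 nM. Going by the values given here, the only step between measured compounds, a 2.4-fold higher number from compound 1 to compound 2 (0.38 log units; beyond the scatter), is modest. Compound 3 `CCc1nc2c(-c3ccc(Cl)cc3Cl)ccnc2n1C(CC)CC` differs from compound 2 by pentan-3-yl in place of 1-cyclobutyl-3-methoxypropyl on an aromatic nitrogen, a change that reaches beyond that step, so the step bears on it only loosely. Compound 3 is therefore expected to fall near compound 1 rather than compound 2, a step of a 1.6-fold lower number from compound 2 to compound 3 (0.20 log units; within the scatter). The estimate for compound 3 is 1.5 nM, within a range of 0.5 nM to 5 nM.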

Compound 3, inhibition constant: 1 nM
Estimate against measurement, compound 3: 1.5-fold (0.18 log units) above, and the stated range covers the measured number.
By their numbers in this assay, from the lowest: compounds 1 and 3 (each within the scatter of the next); then compound 2.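

Putting pentan-3-yl in place of 1-cyclobutylethyl on the aromatic nitrogen gives no change at the digits printed from compound 1 to compound 3 (within the scatter) and so shows that, among these compounds, the four-membered ring is not needed to hold the number at this level. For the compounds shown here, putting pentan-3-yl in place of 1-cyclobutyl-3-methoxypropyl gives a 2.4-fold lower number from compound 2 to compound 3 (0.38 log units; beyond the scatter) and leaves compound 2, the only one carrying a methoxy group, standing apart from the other two. Nothing measured here explains these results. As far as these compounds go, whether an amine or a carboxylic acid on this chain, or a longer chain such as heptan-4-yl, would keep the number at this level remains open.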